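Permeability notes: the anilino group on the shared core

The source may hold more compounds than are shown below. What is called first, only, known or untested is meant among the compounds shown, and "the series" means these compounds.

Compound 1 `CNC(=O)c1cc(Oc2ccc3nc(Nc4cccc(C(C)(C)C)c4)ncc3c2)ccn1` and compound 2 `CCc1ccccc1Nc1ncc2cc(Oc3ccnc(C(=O)NC)c3)ccc2n1` share one core and differ only in the group carried on the nitrogen on the aromatic ring. In an ADME assay on Caco-2 cells (Homo sapiens) for permeability, in the apical to basolateral direction (a lower number here means that the compound crosses the layer more slowly, a higher number that the compound crosses the layer faster), compound 1 gives < 1 10^-6 cm/s, which is a limit of the assay rather than a number. Compound 2 gives < 1 10^-6 cm/s, again a limit. The step that the two limits leave unreadable from compound 1 to compound 2 therefore cannot be read in size or direction, and the limit of < 1 10^-6 cm/s in this assay, at which 2 of the 2 values shown sit, is all the two measured compounds show so far. Compound 3 `CNC(=O)c1cc(Oc2ccc3nc(Nc4ccc(C(F)(F)F)cc4)ncc3c2)ccn1` is not yet measured. It differs from compound 1 in one place: 4-(trifluoromethyl)phenyl in place of 3-(tert-butyl)phenyl on a nitrogen on an aromatic ring. Among the compounds with values here, the single measured step, which also exchanges the group on this nitrogen, is unreadable, so it offers no direction to carry over; both measured values simply sit at the limit. Compound 3 is therefore expected to sit at that limit too, with an estimated step that the limit leaves unreadable from compound 1 to compound 3. The estimate for compound 3 in this assay is 0.5 10^-6 cm/s, within 0.1 10^-6 cm/s to 2 10^-6 cm/s.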

Compound 3, apparent permeability: < 1 10^-6 cm/s
Compound 3: no number, only a limit; the forecaster's own chance of this, stated with the estimate: 80%; the middle value does not contradict the limit.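

In this assay compound 3 gives < 1 10^-6 cm/s, a limit of the assay and not a number, so its steps from compound 1 and compound 2 cannot be read. The size and direction of any effect of the group on this nitrogen stay open, with all three compounds at one limit: the limit of < 1 10^-6 cm/s in this assay, at which 3 of the 3 values shown sit.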